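The source may hold more compounds than are shown below. What is called first, only, known or untested is meant among the compounds shown, and "the series" means these compounds.

Measured compounds in an ADME assay on HT-29 cells (Homo sapiens) for inhibition, read by MTT assay, with a stated time of 72 h; a higher number here means a weaker inhibitor, a lower number a stronger inhibitor:
Compound 1 `C=CC(=O)Nc1cccc(Nc2nc(N/N=C(\C)c3ccc(OC)cc3)ncc2Cl)c1` gives 4560 nM.
Compound 2 `C=CC(=O)Nc1cccc(Nc2nc(N/N=C(\C)c3ccncc3)ncc2Cl)c1` gives 12800 nM.
Compound 3 `COc1ccc(/C=N/Nc2ncc(Cl)c(Nc3cccc(NC(=O)/C=C/CN(C)C)c3)n2)cc1` gives 4820 nM.

The one counted step among these is pyridin-4-yl in place of 4-methoxyphenyl on a carbon with a double bond to nitrogen, which in this assay gave a 2.8-fold higher number from compound 1 to compound 2 (0.45 log units; beyond the scatter). Compound 3 and compound 1 share a related core, but the difference between the two cores is not broken down here; their values in this assay lie within the scatter of one another.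

Compound 4 `CN(C)C/C=C/C(=O)Nc1cccc(Nc2nc(N/N=C/c3ccncc3)ncc2Cl)c1` is not yet measured. It differs from compound 3 by pyridin-4-yl in place of 4-methoxyphenyl on a carbon with a double bond to nitrogen. This is the same kind of change as that from compound 1 to compound 2, though the place is not identical: in compound 1 the carbon with a double bond to nitrogen also carries a saturated chain carbon, whereas in compound 3 its other neighbour is only the double-bonded nitrogen. Because a 2.8-fold higher number from compound 1 to compound 2 (0.45 log units; beyond the scatter) was modest but beyond the scatter, a step of similar size is expected from compound 3, namely a 2.7-fold higher number from compound 3 to compound 4 (0.43 log units; beyond the scatter). Compound 4 is therefore estimated at 13000 nM, with a range from 5500 nM to 30000 nM.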

Compound 4, half-maximal inhibitory concentration: 25200 nM
Beside the measured number, compound 4's estimate is 1.9-fold (0.29 log units) below it, within the range that was stated.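

In this assay, pyridin-4-yl in place of 4-methoxyphenyl on a carbon with a double bond to nitrogen gave a 5.2-fold higher number from compound 3 to compound 4 (0.72 log units; beyond the scatter). Set beside the earlier case, the change carried over in direction, and its size on the two cores cannot be told apart: the same change on two cores in this assay, a 2.8-fold higher number (0.45 log units; beyond the scatter) from compound 1 to compound 2 and a 5.2-fold higher number (0.72 log units; beyond the scatter) from compound 3 to compound 4, 1.9-fold (0.27 log units) apart, within the scatter of two such steps. These two pairs, in one assay, do not show that the step would hold on any further core, nor do they explain why it arises.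

The compounds shown leave open whether a different group in the same place, such as a 4-aminophenyl or 4-carboxyphenyl, would follow pyridin-4-yl or 4-methoxyphenyl. They also leave open how pyridin-3-yl would compare.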